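The source may hold more compounds than are shown below. What is called first, only, known or untested is meant among the compounds shown, and "the series" means these compounds.

Measured so far in an ADME assay on HeLa cells (Homo sapiens) for cytotoxicity, read by resazurin assay, with a stated time of 65 h; on this read-out lower numbers stand for an effect already at smaller amounts and higher numbers for an effect only at larger amounts of compound:
- compound 1 `O=C(Nc1ccc(C(F)(F)F)cc1)c1ccc([N+](=O)[O-])o1`: > 20000 nM (a limit)
- compound 2 `COc1ccc(NC(=O)c2ccc([N+](=O)[O-])o2)cc1C(F)(F)F`: > 20000 nM (a limit)

In this assay compound 2 stands at > 20000 nM, which is a limit of the assay and not a number. Going by the values given here, the series so far offers no measured step, and the only guide is the limit of > 20000 nM in this assay, at which 2 of the 2 values shown sit.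

Compound 3 `C=CCOc1ccc(NC(=O)c2ccc([N+](=O)[O-])o2)cc1C(F)(F)F` differs from compound 2 by vinyl in place of hydrogen on a saturated chain carbon bound to an oxygen on an aromatic ring, so that methoxy becomes allyloxy.

No step beyond the scatter is expected in this assay, and no direction can be given. The expected step of a number no higher from compound 2 to compound 3 (the limit leaves the size open) is therefore small. The estimate for compound 3 is 20000 nM, with an expected range of 8000 nM to 40000 nM. Another report as a limit is the likeliest outcome.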

Compound 3, half-maximal effective concentration: > 20000 nM
Compound 3 was reported as a limit; the forecaster's own chance of this, stated with the estimate: 75%; the middle value sits exactly at the limit.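

Compound 3, like compound 2, is reported only as a limit, so no new step can be read between the two. The compounds shown leave open how methoxy to allyloxy, or any other change on the shared core, would read as a number: the limit of > 20000 nM in this assay, at which 3 of the 3 values shown sit.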